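Trimming the amide side chain of compound 3 to methyl

The source may hold more compounds than are shown below. What is called first, only, known or untested is meant among the compounds shown, and "the series" means these compounds.

Compound 1, `CC(=N)N1CCC(Oc2ccc3ncn(Cc4ccc5ccc(C(=N)N)cc5c4)c3c2)CC1`, gives 50 nM in an assay on isolated protein for inhibition of serine protease 1 (Bos taurus); a lower number here means a stronger inhibitor, a higher number a weaker inhibitor.
Compound 2, `CC(=N)N1CCC(Oc2ccc3c(c2)nc(CCC(=O)O)n3Cc2ccc3ccc(C(=N)N)cc3c2)CC1`, gives 14 nM in this assay.
Compound 3, `CC(=N)N1CCC(Oc2ccc3nc(CCC(N)=O)n(Cc4ccc5ccc(C(=N)N)cc5c4)c3c2)CC1`, gives 4.4 nM in this assay.

Among these three measured compounds, compound 3 stands at the lowest number, and therefore as the strongest inhibitor; compound 2 comes nearest, with a number that is still clearly higher than that of compound 3, and compound 1 sits furthest away. The unmeasured compound 4, `CC(=N)N1CCC(Oc2ccc3nc(C)n(Cc4ccc5ccc(C(=N)N)cc5c4)c3c2)CC1`, keeps the shared core and the two amidine-bearing ends of compound 3 but shortens the side chain on the core: hydrogen in place of carbamoylmethyl on a saturated chain carbon bound to an aromatic carbon.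

Among the measured compounds shown here, one measured step bears on this directly. Going the other way, from a bare hydrogen to the full side chain, an 11-fold lower number from compound 1 to compound 3 (1.06 log units; beyond the scatter). Compound 4 sits between those two structures, carrying a methyl where compound 1 has hydrogen and compound 3 the whole chain. The amide part that compound 3 carries is removed in compound 4, so the number is expected to move back up toward that of compound 1, though a methyl is more than nothing, so not all the way.

For compound 4 the expected step is therefore a 5.7-fold higher number from compound 3 to compound 4 (0.75 log units; beyond the scatter), an estimated 25 nM with a likely range from 8 nM to 70 nM.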

Compound 4, inhibition constant: 18 nM
Beside the measured number, compound 4's estimate is 1.4-fold (0.14 log units) above it; the range from low to high includes it.
By their numbers in this assay, from the lowest: compound 3; then compounds 2 and 4 (each within the scatter of the next); then compound 1.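

The bare hydrogen of compound 1 and the full side chain of compound 3 had shown only one large overall change, and compound 4 divides that change into two parts. Adding just a methyl on the aromatic carbon gives a 2.8-fold lower number from compound 1 to compound 4 (0.44 log units; beyond the scatter) in this assay and so already counts at this position. Replacing carbamoylmethyl with hydrogen on the saturated chain carbon gives a 4.1-fold higher number from compound 3 to compound 4 (0.61 log units; beyond the scatter) in the same test, and since both steps lie beyond the scatter, the gain of the full chain does not rest on its amide end alone. No measurement shown accounts for either step.

The compounds shown leave open how much of the second step belongs to the extra chain carbons and how much to the amide at their end, since a plain propyl chain would be needed to separate the two. They also leave open whether a chain ending in an amine or a hydroxyl, or a longer chain ending in the same amide, would give a number as low as that of compound 3.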